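The source may report more compounds than this note shows. Statements on the series, on what has been measured and on what is new or still open speak of the compounds shown alone.

Measured in a functional assay on HT-29 cells (Homo sapiens) for inhibition, read by luminescence and CellTiter-Glo, with a stated time of 24 h; on this read-out higher numbers stand for an effect only at larger amounts of compound and lower numbers for an effect already at smaller amounts:
Compound 1 `CC(C)n1nc(C(=O)N[C@H]2COc3ccccc3N(C)C2=S)nc1Cc1ccccc1`: 360 nM
Compound 2 `CN1C(=S)[C@@H](NC(=O)c2nc(Cc3ccccc3)n(C3CCOCC3)n2)COc2ccccc21`: 2260 nM

Compound 2 holds the higher of the two numbers in this assay. Compound 3 `CN1C(=S)[C@@H](NC(=O)c2nc(Cc3ccccc3)n(CC3COC3)n2)COc2ccccc21` carries (oxetan-3-yl)methyl in place of oxan-4-yl on an aromatic nitrogen. For the measured compounds named here, the one measured step on that nitrogen, oxan-4-yl in place of isopropyl, is a 6.3-fold higher number from compound 1 to compound 2 (0.80 log units; beyond the scatter). That step is modest but beyond the scatter. A step of no greater size is therefore expected, leaning towards a lower number, though the direction is uncertain. The expected step is a 1.7-fold lower number from compound 2 to compound 3 (0.24 log units; within the scatter). For compound 3 the estimated value is 1300 nM, with an expected range of 350 nM to 5000 nM.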

Compound 3, half-maximal effective concentration: 2830 nM
Compound 3: middle estimate off by 2.2-fold (0.34 log units), on the low side, within the range that was stated.
By their numbers in this assay, from the lowest: compound 1; then compounds 2 and 3 (each within the scatter of the next).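

In this assay, the change from oxan-4-yl to (oxetan-3-yl)methyl gives a 1.3-fold higher number from compound 2 to compound 3 (0.10 log units; within the scatter), so at this nitrogen the two groups cannot be told apart despite their different rings. Measured against isopropyl, the new group gives a 7.9-fold higher number from compound 1 to compound 3 (0.90 log units; beyond the scatter), so the rise seen with oxan-4-yl is no longer confined to that one group. Nothing available explains this result. On these data alone, whether a cyclopropyl group, a plain ethyl chain or a chain ending in an amine would read like isopropyl or like the two oxygen-containing rings remains open.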